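Nitrooxypropanamide chalcones: furan-2-yl replacing 4-methoxyphenyl

This account rests on a few compounds, and the source may have more. Where it says the series, first, only, none or still open, it means among the compounds named here.

Measured so far:
compound 1 `O=C(CBr)Nc1ccc(C(=O)/C=C/c2ccco2)cc1` — 30%
compound 2 `COc1ccc(/C=C/C(=O)c2ccc(NC(=O)C(C)O[N+](=O)[O-])cc2)cc1` — 43%

In a functional assay on the whole organism (strain albino) for inhibition, with Rattus norvegicus as the target, read by paw edema, with stated times of 30 min and 1 h, at a dose of 100 mg/kg by the oral route (a lower number here means less inhibition, a higher number more inhibition at the dose given (going by the name of the read-out)), compound 2 gives 43%, the highest of the two numbers at hand. Its nearest neighbour on this read-out is compound 1, which in this assay gives 30%, a number lower by more than the usual scatter. Among the measured compounds shown here, no pair among the measured compounds differs in one place only, so no single-change step has been measured.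

Compound 3 `CC(O[N+](=O)[O-])C(=O)Nc1ccc(C(=O)/C=C/c2ccco2)cc1` is not yet measured. It differs from compound 2 as follows: furan-2-yl in place of 4-methoxyphenyl on a double-bonded chain carbon bound to a double-bonded chain carbon. The entering furan-2-yl is the same grouping that compound 1 carries on its double-bonded chain carbon, and compound 1 gives 30% in this assay; the amide side chain of compound 3 is otherwise that of compound 2.

Expectation: the step of a number 9 percentage points lower from compound 2 to compound 3 (within the scatter) is expected to be a modest fall, near the edge of the scatter, because compound 1 with the furan-2-yl gives 30%. Compound 3 is accordingly estimated at 34%, in the range 20% to 48%.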

Compound 3, a percentage reported as inhibition, in the whole organism at one dose (the size of the read-out at that dose, not a potency): 41%
The estimate for compound 3 lay 7 percentage points below the measured number; the range from low to high includes it.
By their numbers in this assay, from the lowest: compound 1; then compounds 3 and 2 (each within the scatter of the next).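

In this assay, furan-2-yl in place of 4-methoxyphenyl on a double-bonded chain carbon bound to a double-bonded chain carbon appears as a number 2 percentage points lower from compound 2 to compound 3 (within the scatter), so with the 1-(nitrooxy)ethyl side chain held constant, this single read-out at one dose does not separate the two aromatic groups. With furan-2-yl held constant, 1-(nitrooxy)ethyl in place of bromomethyl on a carbonyl carbon appears as a number 11 percentage points higher from compound 1 to compound 3 (beyond the scatter), making this the only one of the two single changes that lies beyond the scatter, though that holds for this one pair only. No supporting measurement bears on the origin of either step.

As far as these compounds go, it remains open whether furan-2-yl and 4-methoxyphenyl would also stay within the scatter of each other with bromomethyl on the carbonyl carbon, and whether a phenyl group or a thiophen-2-yl group at the same place would do the same. Also open, from the compounds shown here alone, is how much of the step on the carbonyl carbon would persist with a plain methyl group, an aminomethyl group or a longer chain carrying the nitrooxy group in place of 1-(nitrooxy)ethyl.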